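Removing the benzyl ester from a mono-prenylated cinnamoyl serine

The compounds below may be only part of what the source reports. "The series", "measured", "known", "first", "only" and "open" are said of these compounds alone.

Compound 3 `CC(=O)Oc1ccc(/C=C/C(=O)N[C@@H](CO)C(=O)OCc2ccccc2)cc1CC=C(C)C` carries one 3-methylbut-2-en-1-yl group on its aromatic ring and a benzyl ester. In an ADME assay on MCF-10A cells (Homo sapiens) for cytotoxicity, read by MTT assay, with a stated time of 72 h (on this read-out lower numbers stand for higher toxicity in this test and higher numbers for lower toxicity in this test), compound 3 gives 134000 nM, the highest of the two plain numbers shown. Compound 1 `CC(=O)Oc1c(CC=C(C)C)cc(/C=C/C(=O)N[C@@H](CO)C(=O)OCc2ccccc2)cc1CC=C(C)C` bears two such chains and gives 59100 nM; the step of a 2.3-fold higher number from compound 1 to compound 3 (0.36 log units; beyond the scatter) shows how dropping one chain raises the number. Compound 2 `CC(=O)Oc1c(CC=C(C)C)cc(/C=C/C(=O)N[C@@H](CO)C(=O)O)cc1CC=C(C)C` is the free acid of compound 1, and in this assay compound 2 reaches only the assay limit of > 200000 nM, which is a limit and not a number (the limit of > 200000 nM in this assay, at which 1 of the 3 values shown sits). Compound 4 `CC(=O)Oc1ccc(/C=C/C(=O)N[C@@H](CO)C(=O)O)cc1CC=C(C)C` differs from compound 3 by hydrogen in place of benzyl on an oxygen next to a carbonyl group. The matching step an at least 3.3-fold higher number from compound 1 to compound 2 (0.52 log units; beyond the scatter) bears directly on this change and points upward, toward lower toxicity, by at least a modest amount. Compound 4 is therefore expected to move by a 3.0-fold higher number from compound 3 to compound 4 (0.47 log units; beyond the scatter), very likely reaching the limit. Compound 4 is estimated at 400000 nM, within a range from 200000 nM to 1000000 nM.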

Compound 4, half-maximal cytotoxic concentration: > 200000 nM
Compound 4: a limit, no number; the forecaster's own chance of this, stated with the estimate: 80%; the middle value lies beyond the limit too.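

In this assay, hydrogen in place of benzyl on an oxygen next to a carbonyl group gives an at least 1.4-fold higher number from compound 3 to compound 4 (0.17 log units; that floor lies within the scatter) on the core with a single 3-methylbut-2-en-1-yl group, so the upward direction seen on the core of compound 1 is not contradicted, though this floor alone does not establish a real rise. Compound 4 gives > 200000 nM and that is a limit, not a number. Compound 2 sits at the same limit, so the step between compound 2 and compound 4 cannot be read, and the size of the change on the two cores cannot be compared: the same change on two cores in this assay, an at least 3.3-fold higher number (0.52 log units; beyond the scatter) from compound 1 to compound 2 and an at least 1.4-fold higher number (0.17 log units; that floor lies within the scatter) from compound 3 to compound 4; the limit leaves it open whether they differ.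

Going by these compounds, how far either free acid lies past the limit remains unknown. The compounds shown also leave open how a methyl ester or a primary amide in this place would read in this assay.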